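Swapping the aryl group on a shared fused core

The compounds below may be only part of what the source reports. "The series", "measured", "known", "first", "only" and "open" are said of these compounds alone.

Measured compounds:
compound 1 `CC#CC(CC(=O)O)c1ccc(OCc2ccc3nc(-c4ccc(C(F)(F)F)cc4)cn3c2)cc1` — 558 nM
compound 2 `CC#CC(CC(=O)O)c1ccc(OCc2ccn3cc(-c4ccc(CC)cc4)nc3c2)cc1` — 671 nM

In an assay on isolated protein for agonist activity at Free fatty acid receptor 1 (Homo sapiens) (on this read-out lower numbers stand for an effect already at smaller amounts and higher numbers for an effect only at larger amounts of compound), compound 1 gives 558 nM, and compound 2 gives 671 nM. Compound 1 holds the lowest of the two numbers, yet the gap to compound 2 stays within the scatter of repeated measurements, so the two compounds cannot be placed in an order on this basis; both simply sit in the same region of potency.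

Compound 3 `CC#CC(CC(=O)O)c1ccc(OCc2ccc3nc(-c4ccc(F)cc4F)cn3c2)cc1` has not yet been measured in this assay. It keeps the acid-bearing side chain and the shared core of compound 1 and differs in one place: 2,4-difluorophenyl in place of 4-(trifluoromethyl)phenyl on an aromatic carbon. Among the compounds with values here, no pair of measured compounds separates this exact exchange, so its size cannot be read from a known step. With both measured compounds falling so close together, the step from compound 1 to compound 3 a 1.3-fold higher number from compound 1 to compound 3 (0.10 log units; within the scatter) is expected to be small, probably not beyond the scatter. The estimate for compound 3 in this assay is 700 nM, with a range from 250 nM to 2000 nM.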

Compound 3, half-maximal effective concentration: 825 nM
Compound 3: the middle estimate sits 1.2-fold (0.07 log units) below what was measured, within the range that was stated.
By their numbers in this assay, from the lowest: compounds 1, 2 and 3 (each within the scatter of the next).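

In this assay, within the data shown here, putting 2,4-difluorophenyl in place of 4-(trifluoromethyl)phenyl on this aromatic carbon, next to the ring nitrogen, gives a 1.5-fold higher number from compound 1 to compound 3 (0.17 log units; within the scatter), the first step in this set that can be read at a single position. The exchange removes a group of 10 heavy atoms and brings in one of 8, moves the fluorine atoms from a single trifluoromethyl group onto the ring itself, and still leaves a number that cannot be told apart from that of compound 1, so this position tolerates at least this one change on the aryl ring without a measurable shift on this read-out. No measurement shown here bears on why the two aryl groups read alike.

One step at one position cannot show how much this carbon tolerates in general, and a plain phenyl, or a phenyl ring carrying a methoxy group or an amine, could show whether the number moves beyond the scatter. As far as these compounds go, a non-aromatic group here, such as a cyclohexyl ring, is equally open.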